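The source may report more compounds than this note shows. Statements on the series, on what has been measured and on what is new or still open speak of the compounds shown alone.

Measured so far:
- compound 1, `CC(C)CC1C=C(Cl)CCO1`: > 100000 nM
- compound 2, `CCC(C)[C@H]1O[C@@H](C)CC(Cl)=C1[Si](C)(C)C`: > 100000 nM
- compound 3, `C[C@@H]1O[C@H](CCC=C(Br)Br)C([Si](C)(C)C)=C(Cl)[C@H]1C`: 22000 nM

All three were tested in a functional assay on SW1573 cells (Homo sapiens) for antiproliferative activity; a lower number here means a stronger inhibitor of growth, a higher number a weaker inhibitor of growth. For compound 1 the result is only a limit of the assay, > 100000 nM. For compound 2 the result is likewise only a limit, > 100000 nM. Among the compounds with values here, compound 3 is the one compound of the three with an actual number, 22000 nM, and so it stands alone as the only measured value; the other two sit at the limit of > 100000 nM in this assay, at which 2 of the 3 values shown sit, which is not a number that can be ranked against it.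

The next compound, compound 4, `C=CCC[C@H]1O[C@@H](C)[C@H](C)C(Cl)=C1[Si](C)(C)C`, keeps the whole core of compound 3 and changes only the end of the side chain: vinyl in place of 2,2-dibromoethenyl on a saturated chain carbon, two bonds along the chain from a saturated ring carbon. Within the data shown here, no step between two measured compounds of this kind is known, so the size of this change has to be guessed. Losing the two bromines is a clear loss of bulk at the chain end, and with compound 3 already close to the limit, the expectation is a step toward weaker growth inhibition, a 2.3-fold higher number from compound 3 to compound 4 (0.36 log units; beyond the scatter), possibly beyond the scatter. Compound 4 is therefore expected to give about 50000 nM in this assay, somewhere between 15000 nM and 150000 nM, with a fair chance that only a limit is reported.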

Compound 4, concentration for 50% growth inhibition: 23000 nM
For compound 4 the middle estimate is 2.2-fold (0.34 log units) above the measured one, within the range that was stated.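

In this assay, putting vinyl in place of 2,2-dibromoethenyl on a saturated chain carbon, two bonds along the chain from a saturated ring carbon, gives a 1.0-fold higher number from compound 3 to compound 4 (0.02 log units; within the scatter). Within the data shown here, this is the first comparison in the set between two compounds that differ in one place, and it shows that the two bromines can go from the chain end without a readable change in growth inhibition, so the activity of compound 3 does not depend on them. Nothing measured here offers a reason why these two chain ends read alike.

As far as these compounds go, it remains open whether a different end on this chain, such as an amine, a carboxylic acid or a phenyl ring, or a shorter or longer chain, would shift the number in this assay at all. Compound 1 and compound 2 each differ from compound 3 and compound 4 in more than one place, so what the other parts of the shared core contribute also stays unsettled.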